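This account rests on a few compounds, and the source may have more. Where it says the series, first, only, none or still open, it means among the compounds named here.

Two pairs of compounds share a core built around a carbon with a double bond to nitrogen whose other neighbours are amide-type nitrogens. Compound 2 `CS/C(=N\C(=O)c1ccco1)NC(=O)c1ccco1` carries a methylsulfanyl group on that carbon, and compound 1 `C[Se]/C(=N\C(=O)c1ccco1)NC(=O)c1ccco1` differs from it only by a group of 2 heavy atoms (1 carbon, 1 selenium; no ring) in place of a group of 2 heavy atoms (1 carbon, 1 sulfur; no ring), on a carbon with a double bond to nitrogen. In an ADME assay on MCF-10A cells (Homo sapiens) for cytotoxicity, read by MTT assay, with a stated time of 72 h (on this read-out lower numbers stand for stronger inhibition of growth and higher numbers for weaker inhibition of growth), compound 2 gives 46500 nM, and compound 1 gives 40200 nM. The step of a 1.2-fold lower number from compound 2 to compound 1 (0.06 log units; within the scatter) is therefore small. Compound 3 `CS/C(=N\C(=O)c1cc(-c2ccccc2)nc2ccccc12)NC(=O)c1cc(-c2ccccc2)nc2ccccc12` keeps the methylsulfanyl group but sits on a different core; the difference between the core of compound 2 and the core of compound 3 is not broken down here. In this assay compound 3 gives 540 nM, the lowest of the three numbers and beyond the scatter from both others. Going by the values given here, compound 4 `C[Se]/C(=N\C(=O)c1cc(-c2ccccc2)nc2ccccc12)NC(=O)c1cc(-c2ccccc2)nc2ccccc12` is not yet measured; it differs from compound 3 by a group of 2 heavy atoms (1 carbon, 1 selenium; no ring) in place of a group of 2 heavy atoms (1 carbon, 1 sulfur; no ring), on a carbon with a double bond to nitrogen, the same change as the one from compound 2 to compound 1, at the same place. The step of a 1.1-fold lower number from compound 3 to compound 4 (0.06 log units; within the scatter) is expected to be of the same small kind because the earlier step of a 1.2-fold lower number from compound 2 to compound 1 (0.06 log units; within the scatter) stayed within the scatter. Compound 4 is therefore estimated at 470 nM in this assay, with a range from 220 nM to 1000 nM.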

Compound 4, concentration for total growth inhibition: 20100 nM
Beside the measured number, compound 4's estimate is 43-fold (1.63 log units) below it; measured number above the stated range.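

Putting the selenium-containing group in place of methylsulfanyl gives a 37-fold higher number from compound 3 to compound 4 (1.57 log units; beyond the scatter) in this assay, a large step. A step that stayed small on one core therefore did not carry over to the other, so in this series the outcome of this change depends on the core that carries it: the same change on two cores in this assay, a 1.2-fold lower number (0.06 log units; within the scatter) from compound 2 to compound 1 and a 37-fold higher number (1.57 log units; beyond the scatter) from compound 3 to compound 4, 43-fold (1.63 log units) apart, beyond the scatter of two such steps
This rests on one pair of compounds per core in a single assay, so it does not show why the two cores differ or how the change would behave on a third core.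

The compounds shown carry only methylsulfanyl and its selenium counterpart on the carbon with a double bond to nitrogen, so it remains open how a longer chain such as ethyl, or an amine, would behave there on either core. Also open is which part of the core of compound 3 accounts for the gap between the two steps.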